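This account rests on a few compounds, and the source may have more. Where it says the series, first, only, none or still open, it means among the compounds named here.

In a functional assay on HEK293 cells for positive allosteric modulation of metabotropic glutamate receptor 5 (Rattus norvegicus), read by fluorescence and calcium flux (on this read-out lower numbers stand for smaller maximal responses and higher numbers for larger maximal responses), compound 2, `Cc1ccccc1C#Cc1ccc(C(=O)N[C@H](C)C(C)(C)O)nc1`, gives 59.9%. Compound 1, `C[C@@H](NC(=O)c1ccc(C#Cc2ccccc2)cn1)C(C)(C)O`, gives 60.9% in this assay, and the two values sit together: the step of a number 1 percentage points lower from compound 1 to compound 2 (within the scatter) is within the scatter, so neither compound can be called the larger or smaller responder.

Compound 3, `Cc1ccc(C#Cc2ccc(C(=O)N[C@H](C)C(C)(C)O)nc2)cc1`, has not yet been measured. It differs from compound 2 by 4-methylphenyl in place of 2-methylphenyl on a triple-bonded carbon. Going by the values given here, the only measured step, from compound 1 to compound 2, changed a hydrogen into a methyl and moved the maximal response by a number 1 percentage points lower from compound 1 to compound 2 (within the scatter); no measured pair shows what happens when the methyl on that ring changes its position. Among the compounds with values here, with the one available step small, compound 3 is expected to show a step of a number 0.1 percentage points higher from compound 2 to compound 3 (within the scatter), that is, no change beyond the scatter. The estimate for compound 3 in this assay is 60%, with a range from 45% to 75%.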

Compound 3, largest response reached (reported as efficacy), in percent of the reference or control that the assay uses: 63.1%
The estimate for compound 3 lay 3.1 percentage points below the measured number; the measured number falls inside the stated range.
By their numbers in this assay, from the lowest: compounds 2, 1 and 3 (each within the scatter of the next).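

In this assay, going by these compounds alone, putting 4-methylphenyl in place of 2-methylphenyl on a triple-bonded carbon gives a number 3.2 percentage points higher from compound 2 to compound 3 (within the scatter) and is the first measured sign that, for these two groups, the place of the methyl on that ring makes no difference that can be told from the scatter. Compared with the compound that carries hydrogen instead of the methyl, 4-methylphenyl gives a number 2.2 percentage points higher from compound 1 to compound 3 (within the scatter) and so, like 2-methylphenyl, adds no change that stands out from the scatter. No measurement available here explains why the maximal response stays so level. The compounds shown leave open whether a different group on this ring, such as methoxy, chlorine, trifluoromethyl or an amine, would shift the maximal response beyond the scatter.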